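This account rests on a few compounds, and the source may have more. Where it says the series, first, only, none or still open, it means among the compounds named here.

Working notes on the series. Compound 1 `O=C1OC[C@H](Cc2ccccc2O)[C@H]1Cc1ccc(Cl)c(Cl)c1` and compound 2 `COc1ccccc1C[C@H]1COC(=O)[C@@H]1Cc1ccc(Cl)c(Cl)c1` share one core; compound 3 `Oc1ccccc1C[C@H]1COC[C@@H]1Cc1ccc(Cl)c(Cl)c1` and compound 4 `COc1ccccc1C[C@H]1COC[C@@H]1Cc1ccc(Cl)c(Cl)c1` share another, and the difference between the two cores is not broken down here. In a functional assay on HL-60 cells (Homo sapiens) for cytotoxicity, read by WST assay, with a stated time of 48 h (a lower number here means that less compound is needed, a higher number that more compound is needed for the effect), compound 1 gives 33000 nM, compound 2 gives 14000 nM and compound 3 gives 34000 nM. Compound 1 and compound 3 lie within the scatter of each other in this assay.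

Among the compounds with values here, the single counted change in the first pair, (methyl in place of hydrogen on an oxygen on an aromatic ring), gave a 2.4-fold lower number from compound 1 to compound 2 (0.37 log units; beyond the scatter). Compound 4 carries the same change on the core of compound 3, (methyl in place of hydrogen on an oxygen on an aromatic ring), and the place is described in the same words for both pairs, so the change is the same. Within the data shown here, the only measured instance of this change is a 2.4-fold lower number from compound 1 to compound 2 (0.37 log units; beyond the scatter), a modest step on a different core, and that is the whole basis for what follows.

Compound 4 is expected to show a step of about the same size, a 2.3-fold lower number from compound 3 to compound 4 (0.36 log units; beyond the scatter). Compound 4 is therefore estimated at 15000 nM in this assay, with a likely range from 7000 nM to 32000 nM.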

Compound 4, half-maximal effective concentration: 55000 nM
The estimate for compound 4 lay 3.7-fold (0.56 log units) below the measured number, and the stated range ends below it.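

On the core of compound 3, in this assay, the change from hydroxy to methoxy gives a 1.6-fold higher number from compound 3 to compound 4 (0.21 log units; within the scatter), and this step cannot be told apart from the usual scatter. The clear step seen on the core of compound 1 therefore did not carry over to the core of compound 3, and in this series the outcome of the change depends on the core it sits on: the same change on two cores in this assay, a 2.4-fold lower number (0.37 log units; beyond the scatter) from compound 1 to compound 2 and a 1.6-fold higher number (0.21 log units; within the scatter) from compound 3 to compound 4, 3.8-fold (0.58 log units) apart, beyond the scatter of two such steps

This rests on a single pair for each core, so it shows that the step cannot be assumed to transfer, but it does not show why the two cores differ or what a further core would do.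

As far as these compounds go, what an ethoxy group, a longer chain or an amine in place of the hydroxy would give on either core remains open. From the compounds shown here alone, it is also open whether the gap between the two steps would appear in any read-out other than this assay.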